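Varying the Group on the Carbonyl Carbon: Forecast for Compound 4

This account rests on a few compounds, and the source may have more. Where it says the series, first, only, none or still open, it means among the compounds named here.

Compound 1, `Cc1nc(S(C)(=O)=O)ccc1Oc1ncnc(OC2CCN(C(=O)OC(C)C)CC2)c1F`, gives 77% in a functional assay on isolated protein for inhibition of Glucose-dependent insulinotropic receptor (Rattus norvegicus), read by HTRF and cAMP accumulation; on this read-out lower numbers stand for smaller maximal responses and higher numbers for larger maximal responses.
Compound 2, `CCC1(OC(=O)N2CCC(Oc3ncnc(Oc4ccc(S(C)(=O)=O)nc4C)c3F)CC2)CC1`, gives 83%.
Compound 3, `Cc1nc(S(C)(=O)=O)ccc1Oc1ncnc(OC2CCN(C(=O)SC3CC3)CC2)c1F`, gives 80%.

On the numbers shown, compound 3 sits between the other two, with a number 3 percentage points higher from compound 1 to compound 3 (within the scatter) and a number 3 percentage points lower from compound 2 to compound 3 (within the scatter), so all three lie within the scatter of one another. Compound 4, `Cc1nc(S(C)(=O)=O)ccc1Oc1ncnc(OC2CCN(C(=O)C3CCCC3)CC2)c1F`, differs from compound 3 in one place: a group of 5 heavy atoms (5 carbon; one five-membered non-aromatic ring of carbon only) in place of a group of 4 heavy atoms (3 carbon, 1 sulfur; one three-membered non-aromatic ring of carbon only), on a carbonyl carbon. The two measured steps at that carbonyl carbon bear on this change, and both stayed within the scatter. No step beyond the scatter is therefore expected in this assay; the expected change is no change at the digits printed from compound 3 to compound 4 (within the scatter). Compound 4 is estimated at 80%, with a range from 70% to 90%.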

Compound 4, largest response reached (reported as efficacy), in percent of the reference or control that the assay uses: 83%
Compound 4: the middle estimate sits 3 percentage points below what was measured; low and high end bracket the measured number.
By their numbers in this assay, from the lowest: compounds 1, 3, 2 and 4 (each within the scatter of the next).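

Until now the carbonyl carbon had carried only groups linked through oxygen or sulfur; cyclopentyl, made of carbon only, shows that a group without such a link also gives a maximal response in the same range in this assay. All three comparisons stay within the scatter (a number 3 percentage points higher from compound 3 to compound 4 (within the scatter); no change at the digits printed from compound 2 to compound 4 (within the scatter); a number 6 percentage points higher from compound 1 to compound 4 (within the scatter)). Nothing at hand explains this result.

On these data alone, it remains open whether a group linked through an amine nitrogen, or an open-chain group such as tert-butyl, on this carbonyl carbon would stay in that range. The same holds for a cyclopropyl ring bonded directly to the carbonyl carbon.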